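This account rests on a few compounds, and the source may have more. Where it says the series, first, only, none or still open, it means among the compounds named here.

Measured in a functional assay on A-427 cells (Homo sapiens) for cytotoxicity, read by colorimetric assay and MTT assay; on this read-out higher numbers stand for weaker inhibition and lower numbers for stronger inhibition:
Compound 1 `CCN(CC)C(=O)Cn1c(=O)c(-c2ccc(OC)cc2)cc2c(OC)cc(OC)cc21`: 10000 nM
Compound 2 `COc1ccc(-c2cc3c(OC)cc(OC)cc3n(CC(=O)OCc3ccccc3)c2=O)cc1`: 10000 nM
Compound 3 `COc1ccc(-c2cc3c(OC)cc(OC)cc3n(CC(=O)O)c2=O)cc1`: 10000 nM

Compound 3 stands level with compounds 1 and 2 in this assay, and none of the three separates from the others. Compound 4 `COc1ccc(-c2cc3c(OC)cc(OC)cc3n(CCC(=O)OCc3ccccc3)c2=O)cc1` differs from compound 3 by one change: (benzyloxycarbonyl)methyl in place of carboxy on a saturated chain carbon bound to an aromatic nitrogen. For the measured compounds named here, three measured steps bear on it: no change at the digits printed from compound 1 to compound 2 (within the scatter), no change at the digits printed from compound 1 to compound 3 (within the scatter) and no change at the digits printed from compound 2 to compound 3 (within the scatter). The last of these exchanges hydrogen and benzyl on an oxygen, yet it shows no shift. Going by the values given here, no measured step tests the chain itself, so the expectation is uncertain, but no step beyond the scatter is expected in either direction. The estimated step is no change at the digits printed from compound 3 to compound 4 (within the scatter). For compound 4 the expected value is 10000 nM, with an estimated range of 4000 nM to 20000 nM.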

Compound 4, half-maximal inhibitory concentration: 10000 nM
Estimate against measurement, compound 4: no gap at the digits printed; the range from low to high includes it.
By their numbers in this assay, from the lowest: compounds 1, 2, 3 and 4 (each within the scatter of the next).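

In this assay, for the compounds shown here, the chain on the aromatic nitrogen is tested for the first time: (benzyloxycarbonyl)methyl in place of carboxy gives no change at the digits printed from compound 3 to compound 4 (within the scatter). The same group gives no change at the digits printed from compound 2 to compound 4 (within the scatter) in place of benzyloxycarbonyl and no change at the digits printed from compound 1 to compound 4 (within the scatter) in place of diethylcarbamoyl, so neither the added benzyl ester nor the extended chain separates these compounds. Nothing available here offers an explanation for this result. On these data alone, whether an amine or a still longer chain at this place would shift the value remains open, as does any change to the shared core.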